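This account rests on a few compounds, and the source may have more. Where it says the series, first, only, none or still open, it means among the compounds named here.

Working notes on the series. Compound 1 `COc1c(Br)cc(Br)cc1C(=O)Nc1ccc(Sc2nc3ccccc3s2)cc1` carries the (1,3-benzothiazol-2-yl)sulfanyl group and no chloro. In an ADME assay on HEK293 cells (Homo sapiens) for cytotoxicity, read by reporter gene assay and resazurin assay, with a stated time of 48 h (on this read-out higher numbers stand for lower toxicity in this test and lower numbers for higher toxicity in this test), compound 1 gives > 100000 nM, which is a limit of the assay and not a number. Compound 2 `COc1c(Br)cc(Br)cc1C(=O)Nc1cccc(Cl)c1` has the chloro but not the (1,3-benzothiazol-2-yl)sulfanyl group. In this assay compound 2 gives > 100000 nM, again a limit. Compound 3 `COc1c(Br)cc(Br)cc1C(=O)Nc1ccc(Sc2nc3ccccc3s2)c(Cl)c1` combines both substituents. In this assay compound 3 gives > 100000 nM, also a limit. Compound 3 thus stands where every measured member stands: the whole set sits at the limit of > 100000 nM in this assay, at which 3 of the 3 values shown sit, and nothing shown departs from it.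

The two steps that lead into compound 3, a step that the two limits leave unreadable from compound 1 to compound 3 and a step that the two limits leave unreadable from compound 2 to compound 3, run from one limit to another, so neither has a readable size.

Compound 4 `O=C(Nc1ccc(Sc2nc3ccccc3s2)c(Cl)c1)c1cc(Br)cc(Br)c1O` differs from compound 3 by hydrogen in place of methyl on an oxygen on an aromatic ring. Within the data shown here, no measured step bears directly on this change, and the two steps known are unreadable. Because compound 3 sits at the limit of > 100000 nM in this assay, at which 3 of the 3 values shown sit, compound 4 is expected to give 100000 nM in this assay. The range for compound 4 is estimated from 40000 nM to 300000 nM. The expected step of a number no higher from compound 3 to compound 4 (the limit leaves the size open) is therefore none beyond the scatter, and a further limit rather than a number is the likelier outcome.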

Compound 4, half-maximal cytotoxic concentration: 76000 nM
Compound 4: middle estimate off by 1.3-fold (0.12 log units), on the high side; the measured number falls inside the stated range.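

Hydrogen in place of methyl on an oxygen on an aromatic ring gives an at least 1.3-fold lower number from compound 3 to compound 4 (0.11 log units; that floor lies within the scatter), and this is the first change in the series that yields a number rather than a limit in this assay. Only a floor is printed for this step, and that floor lies within the scatter, so the change from methoxy to hydroxy cannot yet be called a real rise in toxicity, though the true step may be larger. The earlier steps cannot be read, which leaves this as the only step with even a floor, and compound 4 alone stands off the limit shared by the other members: the limit of > 100000 nM in this assay, at which 3 of the 4 values shown sit.

The compounds shown leave open how large the step truly is and whether the same change from methoxy to hydroxy would read alike without the chloro or without the (1,3-benzothiazol-2-yl)sulfanyl group. They also do not tell what an ethoxy, an amine or a carboxylic acid in place of the methoxy would give in this assay.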